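Trading 3,4-dichlorophenyl for 4-bromophenyl

A few compounds are considered here, and "the series" means these few. Any claim that something is new, unique, unknown or untested is made for them only; others in the source may bear on it.

Within the data shown here, in a functional assay on SK-OV-3 cells (Homo sapiens) (a higher number here means a weaker inhibitor of growth, a lower number a stronger inhibitor of growth), compound 2 `O=S(=O)(/C=C/c1ccc(Cl)c(Cl)c1)Cc1ccc(Nc2ncnc3ccccc23)cc1` gives 22000 nM, the higher of the two numbers so far, and compound 1 `O=S(=O)(/C=C/c1ccc(F)cc1)Cc1ccc(Nc2ncnc3ccccc23)cc1` gives 2000 nM. Compound 3 `O=S(=O)(/C=C/c1ccc(Br)cc1)Cc1ccc(Nc2ncnc3ccccc23)cc1` changes one group of compound 2: 4-bromophenyl in place of 3,4-dichlorophenyl on a double-bonded chain carbon bound to a double-bonded chain carbon. Among the measured compounds shown here, only one measured step bears on this change, at the same place: an 11-fold higher number from compound 1 to compound 2 (1.04 log units; beyond the scatter). That large step led away from the 4-fluorophenyl of compound 1, and 4-bromophenyl again has a 4-substituted ring without the 3,4-dichloro pattern. A partial return is therefore expected, a 4.4-fold lower number from compound 2 to compound 3 (0.64 log units; beyond the scatter), though a single step is thin evidence. For compound 3 the estimate is 5000 nM, with an expected range from 1500 nM to 18000 nM.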

Compound 3, concentration for 50% growth inhibition: 1000 nM
Compound 3: middle estimate off by 5.0-fold (0.70 log units), on the high side; measured number outside the range, below it.
By their numbers in this assay, from the lowest: compounds 3 and 1 (each within the scatter of the next); then compound 2.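

In this assay the change at this position gives a 22-fold lower number from compound 2 to compound 3 (1.34 log units; beyond the scatter) and so removes the loss seen with 3,4-dichlorophenyl. Exchanging one halogen for another on an aromatic carbon gives a 2.0-fold lower number from compound 1 to compound 3 (0.30 log units; within the scatter), so bromo and fluoro cannot be told apart here, and the 3,4-dichlorophenyl of compound 2 alone stands out among these compounds. No measurement at hand explains this difference.

Still open, on these data alone, is which part of the 3,4-dichloro pattern matters, a question that 3-chlorophenyl and 4-chlorophenyl could separate. Also open, as far as these compounds go, is whether a halogen is needed at all, which plain phenyl or 4-methoxyphenyl could test.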